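Shortening the side chain on a shared anilino core

The compounds below may be only part of what the source reports. "The series", "measured", "known", "first", "only" and "open" are said of these compounds alone.

Measured compounds:
compound 1, `CCCN(c1ccnc(Nc2ccc(C#N)cc2)n1)c1c(F)cc(-c2ccc(C#N)cc2)cc1F`, 212000 nM
compound 2, `N#Cc1ccc(Nc2nccc(N(CCCF)c3c(F)cc(-c4ccc(C#N)cc4)cc3F)n2)cc1`, 241000 nM

Both were tested in an ADME assay on MT4 cells (Homo sapiens) for cytotoxicity, read by MTT assay, with a stated time of 5 days; on this read-out lower numbers stand for higher toxicity in this test and higher numbers for lower toxicity in this test. Compound 2 and compound 1 lie within the scatter of each other, so neither stands apart; the step of a 1.1-fold higher number from compound 1 to compound 2 (0.06 log units; within the scatter) shows this, a fluoro replacing hydrogen far out on the chain attached to the aromatic nitrogen.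

Compound 3, `N#CCN(c1ccnc(Nc2ccc(C#N)cc2)n1)c1c(F)cc(-c2ccc(C#N)cc2)cc1F`, is the next step from compound 2: cyano in place of 2-fluoroethyl on a saturated chain carbon bound to a nitrogen on an aromatic ring. Cut one bond further out, the change reads 3-fluoropropyl to cyanomethyl.

Among the measured compounds shown here, the only step that bears on this is the one from compound 1 to compound 2, which alters the same chain and stays within the scatter. A change at this chain did not move the read-out there, so a step of no more than the scatter is expected here, with no clear direction. Compound 3 is therefore estimated at 220000 nM, with a range from 100000 nM to 450000 nM, meaning an expected step of a 1.1-fold lower number from compound 2 to compound 3 (0.04 log units; within the scatter).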

Compound 3, half-maximal cytotoxic concentration: 206000 nM
For compound 3 the middle estimate is 1.1-fold (0.03 log units) above the measured one; the measured number falls inside the stated range.
By their numbers in this assay, from the lowest: compounds 3, 1 and 2 (each within the scatter of the next).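

The new result carries the earlier finding from a single fluoro swap on the chain to an exchange of the group itself: in this assay the step of a 1.2-fold lower number from compound 2 to compound 3 (0.07 log units; within the scatter) puts cyano in place of 2-fluoroethyl and stays within the scatter. The step of a 1.0-fold lower number from compound 1 to compound 3 (0.01 log units; within the scatter) puts cyano in place of ethyl and also stays within the scatter, so the three compounds cannot be told apart in this test, whichever of these groups the chain carries. No measurement is available here that offers an explanation for this.

As far as these compounds go, it remains open whether this place on the chain would stay as unresponsive with an amine or a carboxylic acid. A longer chain or a phenyl ring at the same place is equally untested by the compounds shown.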